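A few compounds are considered here, and "the series" means these few. Any claim that something is new, unique, unknown or untested is made for them only; others in the source may bear on it.

Compound 1 `O=C(O)C(CCNC(c1ccccc1)(c1ccccc1)c1ccccc1)Cn1ccc(=O)[nH]c1=O` gives 90000 nM in an assay on isolated protein for inhibition of Deoxyuridine 5'-triphosphate nucleotidohydrolase, mitochondrial (Homo sapiens), read by spectrophotometry; a lower number here means a stronger inhibitor, a higher number a weaker inhibitor. Compound 2 `CC(C)(C)[Si](OCCC(Cn1ccc(=O)[nH]c1=O)C(=O)O)(c1ccccc1)c1ccccc1` returns only a limit in this assay, > 100000 nM, so its standing on the numbers is unresolved: the limit of > 100000 nM in this assay, at which 1 of the 2 values shown sits. Compound 3 `CCN(CC)C(=O)C(CCO[Si](c1ccccc1)(c1ccccc1)C(C)(C)C)Cn1ccc(=O)[nH]c1=O` differs from compound 2 by diethylamino in place of hydroxy on a carbonyl carbon. Among the compounds with values here, no measured pair in the set mirrors this change, so nothing here fixes its size or direction; the expected step is a step that the limit leaves unreadable from compound 2 to compound 3, nothing beyond the scatter. Compound 3 is accordingly estimated at 150000 nM, within 30000 nM to 700000 nM, with a fair chance that only a limit is reported.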

Compound 3, inhibition constant: > 100000 nM
Compound 3 was reported as a limit (the forecaster's own chance of this, stated with the estimate: 60%); the middle value lies beyond the limit too.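

Compound 2 and compound 3 both stand only as limits, so no step between them can be read: the limit of > 100000 nM in this assay, at which 2 of the 3 values shown sit.

The compounds shown leave open whether diethylamino in place of hydroxy on a carbonyl carbon shifts the inhibition constant at all, and in which direction.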